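A few compounds are considered here, and "the series" means these few. Any claim that something is new, unique, unknown or untested is made for them only; others in the source may bear on it.

Measured compounds:
- Compound 1 `CC(C(=O)NCc1ccc(C(C)(C)C)nc1N1CCC(Cc2ccccc2)CC1)c1ccc(NS(C)(=O)=O)c(F)c1`: 0.3 nM
- Compound 2 `CCCCCCOc1nc(C(C)(C)C)ccc1CNC(=O)C(C)c1ccc(NS(C)(=O)=O)c(F)c1`: 2.7 nM

In an assay on cells for antagonist activity at transient receptor potential cation channel subfamily V member 1 (Homo sapiens), read by FLIPR and calcium flux, with a stated time of 6 min (a lower number here means a stronger inhibitor, a higher number a weaker inhibitor), compound 1 gives 0.3 nM, while compound 2 gives 2.7 nM. Of the two numbers, compound 2 is the higher one, standing well apart from compound 1, so it is the weaker inhibitor of the pair in this assay.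

Compound 3 `CC(C(=O)NCc1ccc(C(C)(C)C)nc1OCc1ccccc1)c1ccc(NS(C)(=O)=O)c(F)c1` has not yet been measured in this assay. It differs from compound 2 in one place: phenyl in place of pentyl on a saturated chain carbon bound to an oxygen on an aromatic ring. The amide, the shared core and the tert-butyl group are unchanged; only the hexyloxy chain of compound 2 becomes a benzyloxy group in compound 3.

For the measured compounds named here, no measured pair shows this change, so the size of the step is not known. The expectation is a step of a 1.4-fold lower number from compound 2 to compound 3 (0.13 log units; within the scatter), within the usual scatter or at most a modest move toward a lower number. On that basis the value of compound 3 in this assay is estimated at 2 nM, with a range from 0.5 nM to 8 nM.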

Compound 3, inhibition constant: 4.4 nM
For compound 3 the middle estimate is 2.2-fold (0.34 log units) below the measured one, and the stated range covers the measured number.
By their numbers in this assay, from the lowest: compound 1; then compounds 2 and 3 (each within the scatter of the next).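

In this assay, for the compounds shown here, the first comparison at this position, putting phenyl in place of pentyl on a saturated chain carbon bound to an oxygen on an aromatic ring gives a 1.6-fold higher number from compound 2 to compound 3 (0.21 log units; within the scatter). The hexyloxy chain and the benzyloxy group therefore cannot be told apart in this read-out, so on this shared core an open chain and a six-membered aromatic ring at this place give equivalent numbers. Nothing available here offers an explanation for this result.

As far as these compounds go, this rests on a single pair, so it remains open whether the same change would give a similar step on a different core. From the compounds shown here alone, it is also open whether a cyclohexylmethoxy group, a shorter ethoxy chain or a group carrying a carboxylic acid at this place would stay within the scatter of these two compounds.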